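A few compounds are considered here, and "the series" means these few. Any claim that something is new, unique, unknown or untested is made for them only; others in the source may bear on it.

Compound 1 `COc1cc(F)c(CN2C(=O)N(c3cc(OC)nc(OC)c3)S(=O)(=O)c3ccccc32)c(F)c1` gives 0.251 nM in an assay on HEK293 cells for displacement of a labelled ligand from Orexin receptor type 2 (Homo sapiens), read by scintillation counting, with a stated time of 90 min (a higher number here means a weaker inhibitor, a lower number a stronger inhibitor), and holds the lowest number of the three compounds measured. Compound 2 `COc1cc(N2C(=O)N(Cc3c(F)cc(F)cc3F)c3ccccc3S2(=O)=O)cc(OC)n1` gives 1.26 nM in this assay, and compound 3 `COc1cc(N2C(=O)N(Cc3c(F)cc(F)cc3Cl)c3ccccc3S2(=O)=O)cnc1OC` gives 1.59 nM. For the measured compounds named here, the only single-point step in the set, a 5.0-fold higher number from compound 1 to compound 2 (0.70 log units; beyond the scatter), concerns the benzyl group rather than the pyridyl ring. Compound 4 `COc1cc(F)c(CN2C(=O)N(c3ccc(OC)c(OC)n3)S(=O)(=O)c3ccccc32)c(F)c1` differs from compound 1 by 5,6-dimethoxypyridin-2-yl in place of 2,6-dimethoxypyridin-4-yl on an amide-type nitrogen in a ring. Going by the values given here, no measured step isolates a rearrangement of the pyridyl ring, so the direction of any change is open; compound 1 and compound 3, which carry different pyridyl rings but also different benzyl groups, stand apart by more than the scatter. For compound 4 a modest rise is expected, a 4.0-fold higher number from compound 1 to compound 4 (0.60 log units; beyond the scatter), giving an estimated 1 nM within a range of 0.2 nM to 5 nM.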

Compound 4, inhibition constant: 0.2 nM
For compound 4 the middle estimate is 5.0-fold (0.70 log units) above the measured one; low and high end bracket the measured number.
By their numbers in this assay, from the lowest: compounds 4 and 1 (each within the scatter of the next); then compounds 2 and 3 (each within the scatter of the next).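

In this assay, placing 5,6-dimethoxypyridin-2-yl instead of 2,6-dimethoxypyridin-4-yl on the amide-type nitrogen gives a small step (a 1.3-fold lower number from compound 1 to compound 4 (0.10 log units; within the scatter)) and leaves compound 1 and compound 4 indistinguishable. This position next to the ring sulfur therefore accepts both arrangements of the same atoms, at least with the 2,6-difluoro-4-methoxybenzyl group in place. Nothing available explains why the two arrangements read alike. On these data alone, it remains open whether this equivalence holds with the benzyl groups of compound 2 and compound 3. Also open, as far as these compounds go, is how a dimethylamino group in place of either methoxy would fare here.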